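The compounds below may be only part of what the source reports. "The series", "measured", "known", "first", "only" and "open" are said of these compounds alone.

In an ADME assay on BJ cells (Homo sapiens) for cytotoxicity, read by MTT assay, with a stated time of 72 h (on this read-out lower numbers stand for stronger inhibition and higher numbers for weaker inhibition), two compounds have been measured so far. Compound 1 `COc1cc(CNc2ncnc3c2ncn3C2CCCCO2)cc(OC)c1` gives > 100000 nM, which is a limit of the assay and not a number. Compound 2 `COc1cccc(CNc2ncnc3c2ncn3C2CCCO2)c1` gives > 100000 nM, which is also a limit and not a number. Compound 2 therefore stands at the limit of > 100000 nM in this assay, at which 2 of the 2 values shown sit. Compound 3 `COc1cc(CNc2ncnc3c2ncn3C2CCCO2)cc(OC)c1` differs from compound 2 in one place: methoxy in place of hydrogen on an aromatic carbon. This puts methoxy in place of hydrogen on an aromatic carbon of a six-membered aromatic ring of carbon only, meta to a large group and meta to a methoxy group. Among the compounds with values here, no measured step shows what this change does in this assay, so no step beyond the usual scatter is expected, in either direction. The expected step of a number no higher from compound 2 to compound 3 (the limit leaves the size open) is only an estimate. For compound 3 the estimated value is 100000 nM, with an expected range from 50000 nM to 200000 nM, and the assay may well report only a limit again.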

Compound 3, half-maximal inhibitory concentration: > 100000 nM
Compound 3 was reported as a limit (the forecaster's own chance of this, stated with the estimate: 85%); the middle value sits exactly at the limit.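

No step can be read among compound 1, compound 2 and compound 3 in this assay, since each result is a limit and not a number: the limit of > 100000 nM in this assay, at which 3 of the 3 values shown sit. Left open is how far each true value lies past that limit, and whether the added methoxy or oxolan-2-yl in place of oxan-2-yl changes it at all.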